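Z and E double bond in the linked series

The source may hold more compounds than are shown below. What is called first, only, known or untested is meant among the compounds shown, and "the series" means these compounds.

Of the compounds shown here, three have numbers so far in a functional assay on A-431 cells (Homo sapiens) for cytotoxicity, read by MTT assay, with a stated time of 48 h; on this read-out lower numbers stand for stronger inhibition and higher numbers for weaker inhibition. Compound 1 `COC(=O)[C@@H]1CCCN1C(=O)C1=C(C)NC(=S)NC1c1cccc(OCCCCCOc2cccc(C3NC(=S)NC(C)=C3C(=O)N3CCC[C@H]3C(=O)OC)c2)c1` gives 159 ug/mL, compound 2 `CCOC(=O)C1=C(C)NC(=S)NC1c1ccc(OCCCOc2ccc(C3NC(=S)NC(C)=C3C(=O)OCC)cc2OC)c(OC)c1` gives 66 ug/mL, and compound 3 `CCOC(=O)C1=C(C)NC(=S)NC1c1ccc(OC/C=C\COc2ccc(C3NC(=S)NC(C)=C3C(=O)OCC)cc2OC)c(OC)c1` gives 170 ug/mL. Compound 3 sits level with compound 1 within the scatter, while its number is higher than that of compound 2 by a gap beyond the scatter. Compound 4 `CCOC(=O)C1=C(C)NC(=S)NC1c1ccc(OC/C=C/COc2ccc(C3NC(=S)NC(C)=C3C(=O)OCC)cc2OC)c(OC)c1` is its close partner: the two compounds have the same atoms and bonds; at least one stereo element is drawn with a configuration in one of them and without one in the other: 1 of 3 stereo elements differ; a double bond is drawn Z in compound 3 and E in compound 4. A double bond is drawn Z in compound 3 and E in compound 4. Among the compounds with values here, no measured pair shows a change of this kind, so no shift beyond the scatter is expected in this assay. The expected 1.2-fold lower number from compound 3 to compound 4 (0.08 log units; within the scatter) is small and stays within the scatter. For compound 4 the estimate is 140 ug/mL, with an expected range of 65 ug/mL to 300 ug/mL.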

Compound 4, half-maximal inhibitory concentration: 185 ug/mL
The estimate for compound 4 lay 1.3-fold (0.12 log units) below the measured number, within the range that was stated.
By their numbers in this assay, from the lowest: compound 2; then compounds 1, 3 and 4 (each within the scatter of the next).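

In this assay, within the data shown here, the change at the linker double bond gives a 1.1-fold higher number from compound 3 to compound 4 (0.04 log units; within the scatter) and is the first single-place comparison. Among these compounds, the Z and E drawings at this position are therefore not separated by this read-out, which the earlier compounds could not show. One caveat applies to this comparison: the fact that one of compounds 3 and 4 is drawn with a defined configuration and the other without, at the place where they differ
Still open, on these data alone, is whether a triple bond in the linker, or a carboxylic acid in place of the ethyl ester, would move the number beyond the scatter.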